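Two Methoxy Additions on a Curcumin-like Dienone Chain

The source may hold more compounds than are shown below. What is called first, only, known or untested is meant among the compounds shown, and "the series" means these compounds.

Compound 1, `COc1cccc(/C=C/C(=O)/C=C/c2ccc(OCc3cn(CCCCOc4cc(=O)oc5ccccc45)nn3)c(OC)c2)c1`: 47%
Compound 2, `COc1cc(/C=C/C(=O)/C=C/c2ccccc2)ccc1OCc1cn(CCCCOc2cc(=O)oc3ccccc23)nn1`: 36%
Compound 3, `COc1cccc(/C=C/C(=O)/C=C/c2ccc(OCc3cn(CCCOc4cc(=O)oc5ccccc45)nn3)c(OC)c2)c1`: 58%

All three compounds were tested in a functional assay on THP-1 cells (Homo sapiens) for inhibition, read by sulforhodamine B assay, with a stated time of 48 h, tested at 50 uM; on this read-out lower numbers stand for less inhibition of growth and higher numbers for more inhibition of growth at the one concentration tested. Compound 1 differs from compound 2 by methoxy in place of hydrogen on an aromatic carbon, and this change gave a number 11 percentage points higher from compound 2 to compound 1 (beyond the scatter). Compound 3 has the highest of the three numbers, and its steps to compound 1 and to compound 2 are both beyond the scatter. Compound 3 and compound 2 also differ in more than one place, so the difference between their two cores is not broken down here.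

Compound 4, `COc1ccc(/C=C/C(=O)/C=C/c2ccc(OCc3cn(CCCOc4cc(=O)oc5ccccc45)nn3)c(OC)c2)cc1OC`, has not yet been measured. It differs from compound 3 by methoxy in place of hydrogen on an aromatic carbon. Among the compounds with values here, this is the same kind of change as the one from compound 2 to compound 1, but not the same change: in the earlier pair the entering methoxy sits meta to a large group, whereas in compound 4 it sits ortho to a methoxy group and para to a large group.

The step expected here is a number 6 percentage points higher from compound 3 to compound 4 (within the scatter), a size that rests on the earlier step of a number 11 percentage points higher from compound 2 to compound 1 (beyond the scatter) measured for a methoxy entering on the same ring. Compound 4 is therefore estimated to give 64% in this assay, with a likely range from 50% to 78%.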

Compound 4, percent growth inhibition at one concentration: 73%
Compound 4: middle estimate off by 9 percentage points, on the low side; the range from low to high includes it.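

Turning 3-methoxyphenyl into 3,4-dimethoxyphenyl gave a number 15 percentage points higher from compound 3 to compound 4 (beyond the scatter) in this assay. Placed beside the earlier methoxy step, this suggests that the gain in growth inhibition carried over from one core to the other, with both steps pointing the same way and their sizes not distinguishable: the same change on two cores in this assay, a number 11 percentage points higher (beyond the scatter) from compound 2 to compound 1 and a number 15 percentage points higher (beyond the scatter) from compound 3 to compound 4, 4 percentage points apart, within the scatter of two such steps. Within the data shown here, this rests on only two pairs, with the methoxy entering at a different place in each, so it does not establish a general rule for the series, does not separate the effect of place from that of core, and describes only one cell line at one concentration.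

The compounds shown leave open how a hydroxyl group, an amine or a carboxylic acid would compare with methoxy at the place where it enters in compound 4, which would test whether the gain is specific to methoxy. They also leave open whether the same step would appear on a core with a longer linking chain, and whether it would hold across a full concentration series rather than at a single test concentration.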